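A few compounds are considered here, and "the series" means these few. Any claim that something is new, unique, unknown or untested is made for them only; others in the source may bear on it.

Measured so far in a functional assay on P388 cells (Mus musculus) for cytotoxicity, read by sulforhodamine B assay; on this read-out lower numbers stand for an effect already at smaller amounts and higher numbers for an effect only at larger amounts of compound:
compound 1 `C=C1CC[C@@H]2[C@](C)(COC(C)=O)[C@H](OC(C)=O)CC[C@@]2(C)[C@@H]1C/C=C1/C(=O)OC[C@H]1OC(C)=O`: 1.4 uM
compound 2 `C=C1CC[C@@H]2[C@](C)(CO[Si](c3ccccc3)(c3ccccc3)C(C)(C)C)[C@H](OC(C)=O)CC[C@@]2(C)[C@@H]1C/C=C1/C(=O)OC[C@H]1O`: 0.5 uM
compound 3 `C=C1CC[C@@H]2[C@](C)(CO)[C@H](OC(C)=O)CC[C@@]2(C)[C@@H]1C/C=C1/C(=O)OC[C@H]1OC(C)=O`: 0.69 uM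

Compound 1 has the highest of these three numbers in this assay, and compounds 2 and 3 both stand lower, beyond the scatter.

Compound 4 `C=C1CC[C@@H]2[C@](C)(CO[Si](C)(C)C(C)(C)C)[C@H](OC(C)=O)CC[C@@]2(C)[C@@H]1C/C=C1/C(=O)OC[C@H]1OC(C)=O` keeps the core of compound 1 and differs from it in one place: a group of 7 heavy atoms (6 carbon, 1 silicon; no ring) in place of a group of 3 heavy atoms (2 carbon, 1 oxygen; no ring), on an oxygen on a saturated carbon.

The measured step closest to this change is a 2.0-fold lower number from compound 1 to compound 3 (0.31 log units; beyond the scatter). It is modest, and it also removes an acetyl from an oxygen on a saturated carbon, though only hydrogen enters there. Compound 2 (0.5 uM) also carries a silicon-containing group on an oxygen on a saturated carbon. However, it differs from compound 1 in a second place as well, so it offers no clean step. Among the compounds with values here, no measured step shows a silicon-containing group replacing acetyl with everything else unchanged.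

Both compound 3 and compound 2 have lower numbers than compound 1, so a modest move towards a lower number is expected, resting on very few compounds. The expected change is a 2.0-fold lower number from compound 1 to compound 4 (0.30 log units; within the scatter). Compound 4 is estimated at 0.7 uM, with an expected range of 0.25 uM to 2 uM.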

Compound 4, concentration for half-maximal effect: 0.34 uM
Compound 4: the middle estimate sits 2.1-fold (0.31 log units) above what was measured, within the range that was stated.
By their numbers in this assay, from the lowest: compounds 4, 2 and 3 (each within the scatter of the next, the first and the last beyond it); then compound 1.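

In this assay the oxygen on a saturated carbon that carries acetyl in compound 1 accepts the group of 7 heavy atoms (6 carbon, 1 silicon; no ring) with a fall in the number (a 4.1-fold lower number from compound 1 to compound 4 (0.61 log units; beyond the scatter)), so a group well beyond acetyl in atom count is accepted at this place. The free oxygen is not the best of the groups seen here either, as the same silicon group stands lower than hydrogen on this oxygen (a 2.0-fold lower number from compound 3 to compound 4 (0.31 log units; beyond the scatter)), which gives an order of silicon group, then hydrogen, then acetyl across the three compounds that differ only at this place. No measurement in hand accounts for that order.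

Three groups on one oxygen cannot show whether the number follows the size of the group or something particular to the silicon group, and a methyl ether, a benzyl ether or a longer acyl chain here would separate those readings. Also open, from the compounds shown here alone, is how an amine or a carboxylic acid carried on this oxygen would read.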